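Amide series on a shared chlorinated core: inactive pair

The compounds below may be only part of what the source reports. "The series", "measured", "known", "first", "only" and "open" are said of these compounds alone.

Measured so far:
compound 1 `Cc1cc(Cl)ccc1C(=O)Nc1ccc(Cl)c(-c2nnc3c(Cl)cccn23)c1` — > 100000 nM
compound 2 `CS(=O)(=O)c1ccc(C(=O)Nc2ccc(Cl)c(-c3nnc4c(Cl)cccn34)c2)c(Cl)c1` — > 100000 nM

Both compounds were tested in a functional assay on HeLa cells (Homo sapiens) for antiproliferative activity, read by MTT assay, with a stated time of 72 h; a lower number here means a stronger inhibitor, a higher number a weaker inhibitor. For compound 1 the result is not a number but a limit of the assay, > 100000 nM. For compound 2 the result is likewise only a limit, > 100000 nM. Within the data shown here, compound 2 therefore stands at the limit itself, with no number on either side of it; the only other value shown is also a limit, see (the limit of > 100000 nM in this assay, at which 2 of the 2 values shown sit), so no step between measured compounds can be sized.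

The next compound, compound 3 `O=C(Nc1ccc(Cl)c(-c2nnc3c(Cl)cccn23)c1)c1ccccc1Cl`, differs from compound 2 in one place: hydrogen in place of methylsulfonyl on an aromatic carbon — hydrogen in place of methylsulfonyl on an aromatic carbon. Nothing in the measured data ties this position to any shift in this assay, since compound 1 and compound 2 both sit at the limit.

For compound 3 the expectation is that the value stays at or near the limit, which in this assay would mean 150000 nM (range 40000 nM to 500000 nM); the step that the limit leaves unreadable from compound 2 to compound 3 is estimated as no change beyond the scatter.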

Compound 3, half-maximal inhibitory concentration: > 100000 nM
Compound 3 ended at the assay's limit; the forecaster's own chance of this, stated with the estimate: 80%; the middle value is on the limit's open side.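

In this assay, compound 3 gives > 100000 nM, a limit of the assay. The steps to compound 3 from compound 1 and compound 2 cannot be read, so the series yields no size of change: the limit of > 100000 nM in this assay, at which 3 of the 3 values shown sit. The compounds shown leave open whether any amide on the shared core can give a numerical value in this assay.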